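Methoxy for methyl on two related cores: lipophilicity notes

This account rests on a few compounds, and the source may have more. Where it says the series, first, only, none or still open, it means among the compounds named here.

Measured compounds, read in a physicochemical assay for lipophilicity, measured as octanol-water partition; a higher number here means a more lipophilic compound, a lower number a more polar compound:
compound 1, `Cc1ccc(-c2c(C#N)[n+]([O-])c3cc(Cl)ccc3[n+]2[O-])cc1`: 2.6
compound 2, `COc1ccc(-c2c(C#N)[n+]([O-])c3cc(Cl)ccc3[n+]2[O-])cc1`: 2.09
compound 3, `Cc1ccc(-c2c(C#N)[n+]([O-])c3cc(F)c(F)cc3[n+]2[O-])cc1`: 2.87

For the measured compounds named here, the one counted step is methoxy in place of methyl on an aromatic carbon, giving a number 0.51 log units lower from compound 1 to compound 2 (beyond the scatter). How the core of compound 3 differs from the core of compound 1 is not broken down here; the two values lie within the scatter of each other, and compound 3 stands beyond the scatter only from compound 2.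

Compound 4, `COc1ccc(-c2c(C#N)[n+]([O-])c3cc(F)c(F)cc3[n+]2[O-])cc1`, is not yet measured. It carries the same change as compound 2 carries relative to compound 1: methoxy in place of methyl on an aromatic carbon. The place lines agree word for word, so this is the same change on the other core. Going by the values given here, compound 4 is expected to follow the earlier step, a number 0.51 log units lower from compound 3 to compound 4 (beyond the scatter), because compound 3 gives 2.87 and the step of a number 0.51 log units lower from compound 1 to compound 2 (beyond the scatter) is the only guide available. Compound 4 is thus estimated at 2.36, between 2.1 and 2.65.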

Compound 4, partition coefficient: 2.09
Beside the measured number, compound 4's estimate is 0.27 log units above it; the measured number lies below the stated range.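

In this assay, methoxy in place of methyl on an aromatic carbon gives a number 0.78 log units lower from compound 3 to compound 4 (beyond the scatter) and so runs the same way as a number 0.51 log units lower from compound 1 to compound 2 (beyond the scatter) with both steps beyond the scatter. The direction of the change therefore carries from the core of compound 1 to the core of compound 3, but two cores make only a single repeat, and nothing here shows that the size of the step is fixed or that the direction would hold on a further core. No measurement bearing on the reason for either step is at hand.

The compounds shown leave open how an amine, a carboxylic acid or a longer chain such as ethoxy would read at this same place on the aromatic ring.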